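The source may report more compounds than this note shows. Statements on the series, on what has been measured and on what is new or still open speak of the compounds shown alone.

Compound 1 `COc1ccc(C2=NN(C(=O)C(C)Br)C(c3ccco3)C2)cc1OC` is tested in a functional assay on the whole organism (strain albino) for inhibition, with Rattus norvegicus as the target, read by paw edema, with stated times of 30 min and 1 h, at a dose of 100 mg/kg by the oral route (a higher number here means more inhibition at the dose given (going by the name of the read-out), a lower number less inhibition), where compound 1 gives 22%. Compound 2 `COc1ccc(C2CC(c3ccc(OC)c(OC)c3)=NN2C(=O)C(C)Br)c(OC)c1` differs from it by 2,4-dimethoxyphenyl in place of furan-2-yl on a saturated ring carbon, and in this assay compound 2 gives 58%, a step of a number 36 percentage points higher from compound 1 to compound 2 (beyond the scatter). Compound 3 `COc1ccc(C2=NN(C(=O)C(C)O[N+](=O)[O-])C(c3ccco3)C2)cc1OC` differs from compound 1 by nitrooxy in place of bromo on a saturated chain carbon bound to a carbonyl carbon and a saturated chain carbon; in this assay compound 3 gives 35%, a step of a number 13 percentage points higher from compound 1 to compound 3 (beyond the scatter).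

Compound 4 `COc1ccc(C2CC(c3ccc(OC)c(OC)c3)=NN2C(=O)C(C)O[N+](=O)[O-])c(OC)c1` carries the change (2,4-dimethoxyphenyl in place of furan-2-yl on a saturated ring carbon), the same kind of change as that from compound 1 to compound 2, the difference around the place being that the ring atom next to the changed carbon now bears a group of 8 heavy atoms rather than a (1-bromoethyl)carbonyl group (5 heavy atoms). Compound 4 is expected to show a step of a number 35 percentage points higher from compound 3 to compound 4 (beyond the scatter), close to the earlier step because a number 36 percentage points higher from compound 1 to compound 2 (beyond the scatter). In this assay compound 4 is therefore estimated at 70%, with a range from 52% to 86%.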

Compound 4, a percentage reported as inhibition, in the whole organism at one dose (the size of the read-out at that dose, not a potency): 44%
Beside the measured number, compound 4's estimate is 26 percentage points above it, outside the stated range (below it).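

In this assay the change to 2,4-dimethoxyphenyl in place of furan-2-yl gives only a number 9 percentage points higher from compound 3 to compound 4 (within the scatter), so on the nitrooxy compounds it does not carry over at its earlier size: the same change on two cores in this assay, a number 36 percentage points higher (beyond the scatter) from compound 1 to compound 2 and a number 9 percentage points higher (within the scatter) from compound 3 to compound 4, 27 percentage points apart, beyond the scatter of two such steps. The exchange of bromo for nitrooxy depends on its surroundings as well, giving a number 14 percentage points lower from compound 2 to compound 4 (beyond the scatter) on the 2,4-dimethoxyphenyl compounds, against a rise on the furan-2-yl compounds: the same change on two cores in this assay, a number 13 percentage points higher (beyond the scatter) from compound 1 to compound 3 and a number 14 percentage points lower (beyond the scatter) from compound 2 to compound 4, 27 percentage points apart, beyond the scatter of two such steps. The four compounds show that the two changes do not simply add up, but they do not show why, nor how either change would behave on any other core.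

As far as these compounds go, whether a plain phenyl or a thiophene at this place would follow the furan-2-yl or the 2,4-dimethoxyphenyl compounds stays open. So does the outcome with a chloro or a hydroxy group in place of bromo and nitrooxy.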